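Ester side chain on the pyrrolidine nitrogen

This account rests on a few compounds, and the source may have more. Where it says the series, first, only, none or still open, it means among the compounds named here.

Measured so far in a functional assay on HCC827 cells (Homo sapiens) for antiproliferative activity, read by MTT assay, with a stated time of 72 h; on this read-out lower numbers stand for stronger inhibition and higher numbers for weaker inhibition:
compound 1 `CN1CCN(c2ccc(Nc3ncc4nc(Nc5ccccc5)n([C@H]5CCNC5)c4n3)cc2)CC1` gives 530 nM
compound 2 `CN1CCN(c2ccc(Nc3ncc4nc(Nc5ccccc5)n([C@@H]5CCNC5)c4n3)cc2)CC1` gives 65 nM
compound 3 `CN1CCN(c2ccc(Nc3ncc4nc(Nc5ccc(F)cc5)n([C@H]5CCNC5)c4n3)cc2)CC1` gives 1220 nM

Compound 3 stands highest of the three numbers in this assay, with compound 1 nearest and compound 2 furthest. The two steps measured so far are an 8.2-fold lower number from compound 1 to compound 2 (0.91 log units; beyond the scatter), which rests on (the fact that compounds 1 and 2 differ only in the configuration as drawn), and a 2.3-fold higher number from compound 1 to compound 3 (0.36 log units; beyond the scatter). Both leave the ring amine untouched.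

Compound 4 `CCOC(=O)CN1CC[C@H](n2c(Nc3ccc(F)cc3)nc3cnc(Nc4ccc(N5CCN(C)CC5)cc4)nc32)C1` is next for this assay. Relative to compound 3 the change is (ethoxycarbonyl)methyl in place of hydrogen on an amine nitrogen in a ring; cut one bond further out it reads pyrrolidin-3-yl to 1-((ethoxycarbonyl)methyl)pyrrolidin-3-yl. For the measured compounds named here, neither measured step alters this nitrogen, so no measured step bears directly on the change, and the series gives no guidance on direction. The fluoro group and the drawn configuration of compound 3 are carried over unchanged. The expectation is therefore a step of a 1.2-fold lower number from compound 3 to compound 4 (0.09 log units; within the scatter), not beyond the scatter. Compound 4 is estimated at 1000 nM in this assay, within a range of 300 nM to 3500 nM.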

Compound 4, half-maximal inhibitory concentration: 1810 nM
For compound 4 the middle estimate is 1.8-fold (0.26 log units) below the measured one; low and high end bracket the measured number.
By their numbers in this assay, from the lowest: compound 2; then compound 1; then compounds 3 and 4 (each within the scatter of the next).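

For the compounds shown here, compounds 1 to 3 all keep hydrogen on the amine nitrogen of the five-membered ring, so compound 4 gives the first reading at this position. In this assay the entry of (ethoxycarbonyl)methyl gives a 1.5-fold higher number from compound 3 to compound 4 (0.17 log units; within the scatter), so in this pair, with the fluoro group and the drawn configuration of compound 3 held, the hydrogen on this nitrogen can be replaced by a group of this size without a shift beyond the scatter. Going by these compounds alone, nothing at hand accounts for this outcome, and the single pair gives no basis for assigning any role to the ester.

Still open, on these data alone, is whether the same tolerance holds on the opposite configuration, that of compound 2, which gives 65 nM and carries neither the fluoro group nor any substituent on this nitrogen. Also open, as far as these compounds go, is how this nitrogen responds to other groups, such as a carboxylic acid in place of the ethyl ester, a primary amide, a longer chain ending in the same ester, or a plain methyl.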